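Amino for nitro on a benzimidazole-type cytotoxicity series

The source may hold more compounds than are shown below. What is called first, only, known or untested is meant among the compounds shown, and "the series" means these compounds.

Measured compounds:
compound 1, `COc1ccc(-c2nc3cc(C(F)(F)F)ccc3[nH]2)cc1`, 2000 nM
compound 2, `COc1ccc(-c2nc3cc(C(F)(F)F)ccc3[nH]2)c([N+](=O)[O-])c1`, 85000 nM

In an ADME assay on MT4 cells (Homo sapiens) for cytotoxicity, read by MTT assay, with a stated time of 96 h (on this read-out higher numbers stand for lower toxicity in this test and lower numbers for higher toxicity in this test), compound 2 stands highest of the two numbers, its nearest neighbour being compound 1 with a 43-fold higher number from compound 1 to compound 2 (1.63 log units; beyond the scatter) between them. Compound 3, `COc1ccc(-c2nc3cc(C(F)(F)F)ccc3[nH]2)c(N)c1`, is not yet measured. It differs from compound 2 as follows: amino in place of nitro on an aromatic carbon. Among the measured compounds shown here, no measured step covers this exact change. For the measured compounds named here, the one step that bears on it is the earlier one from compound 1 to compound 2, which was large and went upward when nitro replaced hydrogen; removing nitro again may undo part of that. For compound 3 a step of a 5.7-fold lower number from compound 2 to compound 3 (0.75 log units; beyond the scatter) in this assay is therefore expected, downward. Compound 3 is estimated at 15000 nM, within 3000 nM to 80000 nM.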

Compound 3, half-maximal cytotoxic concentration: 5000 nM
The estimate for compound 3 lay 3.0-fold (0.48 log units) above the measured number; the range from low to high includes it.
By their numbers in this assay, from the lowest: compound 1; then compound 3; then compound 2.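

Replacing nitro with amino takes back most of the earlier rise in this assay (a 17-fold lower number from compound 2 to compound 3 (1.23 log units; beyond the scatter)), so not every group at this position lifts the number as far as nitro does. Amino still stands apart from the hydrogen of compound 1 (a 2.5-fold higher number from compound 1 to compound 3 (0.40 log units; beyond the scatter)), though this step is only modest. Nothing measured here explains the difference between these groups. From the compounds shown here alone, it remains open whether a methyl group, a chlorine atom or a carboxylic acid at this position would fall nearer compound 1 or compound 2. Whether amino and nitro would differ as much on another carbon of the same ring is also unknown.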